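Chloro to bromo on the aryl ring: expected effect

The source may report more compounds than this note shows. Statements on the series, on what has been measured and on what is new or still open speak of the compounds shown alone.

Among the compounds with values here, compound 2 `Cc1[nH]nc(N)c1-c1cccc(Cl)c1` gives 93400 nM in an assay on Sf9 cells for inhibition of inhibitor of nuclear factor kappa-B kinase subunit epsilon (Homo sapiens), read by ADP-Glo, with a stated time of 60 min (a lower number here means a stronger inhibitor, a higher number a weaker inhibitor), the only number measured so far. In this assay compound 1 `Cc1cccc(-c2c(N)n[nH]c2C)c1` returns a limit, > 100000 nM. Within the data shown here, the one measured step, an at least 1.0-fold lower number from compound 1 to compound 2 (0.02 log units; that floor lies within the scatter), is bounded by the limit (the limit of > 100000 nM in this assay, at which 1 of the 2 values shown sits), so it sets only a floor that lies within the scatter. Compound 3 `Cc1[nH]nc(N)c1-c1cccc(Br)c1` carries bromo in place of chloro on an aromatic carbon. Among the measured compounds shown here, no measured step addresses a bromo-for-chloro exchange, and the single halogen-for-methyl step gives no ground for a large move. Near compound 2, compound 3 is therefore estimated at 80000 nM in this assay, between 30000 nM and 200000 nM. The expected step of a 1.2-fold lower number from compound 2 to compound 3 (0.07 log units; within the scatter) lies within the scatter.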

Compound 3, half-maximal inhibitory concentration: > 100000 nM
Compound 3 was reported as a limit; the forecaster's own chance of this, stated with the estimate: 40%; middle value at least 1.2-fold (0.09 log units) from the limit.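

At this place, on an aromatic carbon meta to a group of 7 heavy atoms, bromo in place of chloro can only be bounded in this assay: an at least 1.0-fold higher number from compound 2 to compound 3 (0.02 log units; that floor lies within the scatter). The value of compound 3 is a limit, so the exchange has no readable size, and the floor gives no separation from compound 2. The step between compound 1 and compound 3 cannot be read, and most of the values shown now rest at one limit: the limit of > 100000 nM in this assay, at which 2 of the 3 values shown sit.

From the compounds shown here alone, it stays open whether any group on this aromatic carbon gives a value clear of that limit. An amine or a carboxylic acid in place of the bromo would test this.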